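Notes on compound 4 against the three measured compounds

This account rests on a few compounds, and the source may have more. Where it says the series, first, only, none or still open, it means among the compounds named here.

Compound 1 `COc1cc(CC(O)c2ccc(-c3ccc([N+](=O)[O-])cc3)cc2)c([N+](=O)[O-])cc1OC` gives 21000 nM in an ADME assay on HeLa Rh cells (Homo sapiens) for cytotoxicity, read by microscopy (a lower number here means that less compound is tolerated, a higher number that more compound is tolerated), the highest number among the three measured compounds. Compound 2 `COc1cc(CC(O)c2ccc(-c3cccc(F)c3)cc2)c([N+](=O)[O-])cc1OC` gives 7400 nM in this assay, and compound 3 `COc1cc(CC(O)c2ccc(-c3ccccc3[N+](=O)[O-])cc2)c([N+](=O)[O-])cc1OC` gives 9500 nM. Both departures from compound 1 lowered the number: a 2.8-fold lower number from compound 1 to compound 2 (0.45 log units; beyond the scatter) and a 2.2-fold lower number from compound 1 to compound 3 (0.34 log units; beyond the scatter). Between compound 2 and compound 3 the step is a 1.3-fold higher number from compound 2 to compound 3 (0.11 log units; within the scatter). Compound 4 `COc1cc(CC(O)c2ccc(-c3cccnc3)cc2)c([N+](=O)[O-])cc1OC` differs from compound 1 by pyridin-3-yl in place of 4-nitrophenyl on an aromatic carbon. Both measured exchanges of the 4-nitrophenyl bear on this change, and each produced a modest lowering beyond the scatter, so a modest lowering is expected here as well, a 2.3-fold lower number from compound 1 to compound 4 (0.37 log units; beyond the scatter). Compound 4 is therefore estimated at 9000 nM, with a range from 4500 nM to 18000 nM.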

Compound 4, half-maximal cytotoxic concentration: > 263000 nM
Compound 4: a limit, no number (the forecaster's own chance of this, stated with the estimate: 10%); at least 29-fold (1.46 log units) between middle value and limit.
By their numbers in this assay, from the lowest: compounds 2 and 3 (each within the scatter of the next); then compound 1. At a limit, above all of these: compound 4.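

In this assay compound 4 gives > 263000 nM, which is a limit of the assay and not a number. This position, on an aromatic carbon para to a large group, therefore allows far larger moves than the earlier exchanges showed: an at least 12-fold higher number from compound 1 to compound 4 (1.09 log units; beyond the scatter), an at least 27-fold higher number from compound 3 to compound 4 (1.44 log units; beyond the scatter) and an at least 35-fold higher number from compound 2 to compound 4 (1.55 log units; beyond the scatter). Among the four compounds, pyridin-3-yl is the only group with a hetero atom in its ring, and the only one to reach a limit.

From the compounds shown here alone, the true value of compound 4 remains open. So does whether the ring nitrogen or its location matters, which pyridin-2-yl, pyridin-4-yl or a saturated amine such as morpholine at this carbon would help separate.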